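Swapping the Hydroxyphenyl for a Dichlorophenyl

This account rests on a few compounds, and the source may have more. Where it says the series, first, only, none or still open, it means among the compounds named here.

Compound 1 `O=C(CSc1nnc(-c2ccncc2)o1)N/N=C/c1ccc(O)cc1`: 7940 nM
Compound 2 `O=C(CSc1nnc(-c2ccncc2)o1)N/N=C/c1ccccc1F`: 24000 nM
Compound 3 `O=C(CSc1nnc(-c2ccncc2)o1)N/N=C/c1cc(Cl)ccc1O`: 5470 nM

All three values come from a functional assay on BGC-823 cells (Homo sapiens) for cytotoxicity, read by MTT assay, with a stated time of 48 h; a lower number here means a stronger inhibitor, a higher number a weaker inhibitor. Compound 1 stands second highest of the three numbers; compound 3 sits within the scatter of it, while compound 2 lies clearly beyond it. Compound 4 `O=C(CSc1nnc(-c2ccncc2)o1)N/N=C/c1ccc(Cl)cc1Cl` differs from compound 1 in one place: 2,4-dichlorophenyl in place of 4-hydroxyphenyl on a carbon with a double bond to nitrogen. Among the measured compounds shown here, two measured steps bear on this: a 3.0-fold higher number from compound 1 to compound 2 (0.48 log units; beyond the scatter) and a 1.5-fold lower number from compound 1 to compound 3 (0.16 log units; within the scatter). Like compound 2, compound 4 has no hydrogen-bond donor on this ring, which in that step cost potency; like compound 3 it carries chlorine, which changed little. A modest weakening is therefore expected, about a 1.6-fold higher number from compound 1 to compound 4 (0.21 log units; within the scatter). Compound 4 is estimated at 13000 nM, ranging from 5000 nM to 32000 nM.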

Compound 4, half-maximal inhibitory concentration: 35600 nM
Estimate against measurement, compound 4: 2.7-fold (0.44 log units) below; measured number outside the range, above it.
By their numbers in this assay, from the lowest: compounds 3 and 1 (each within the scatter of the next); then compounds 2 and 4 (each within the scatter of the next).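

Chlorine on this ring does not by itself keep the activity: removing the hydroxyl-bearing ring gives a 4.5-fold higher number from compound 1 to compound 4 (0.65 log units; beyond the scatter) and a 6.5-fold higher number from compound 3 to compound 4 (0.81 log units; beyond the scatter). The two rings without a hydroxyl group now fall together, with a 1.5-fold higher number from compound 2 to compound 4 (0.17 log units; within the scatter), while both rings with one give lower numbers, and no listed compound goes against this split. No measurement shown explains the split. Still open, as far as these compounds go, is whether an amine or a methoxy group in place of the hydroxyl would keep the lower numbers.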